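Swapping the chain end of compound 1

The compounds below may be only part of what the source reports. "The series", "measured", "known", "first", "only" and "open" are said of these compounds alone.

Compound 1 `Cn1cc(-c2ccccc2Oc2ccccc2)c2cc(C(=O)NCCCCCCC(=O)NO)[nH]c2c1=O` gives 180 nM 
Compound 2 `CC(C)Oc1ccc(C(C)(C)O)cc1-c1cn(C)c(=O)c2[nH]c(C(=O)NCc3ccc(C(=O)Nc4ccccc4N)cc3)cc12` gives 40 nM 
Compound 3 `Cn1cc(-c2cc(C(C)(C)O)ccc2Oc2ccc(F)cc2F)c2cc(C(=O)NCc3ccc(C(=O)NO)cc3)[nH]c2c1=O` gives 190 nM 

In a functional assay on MV4-11 cells (Homo sapiens) for antiproliferative activity, read by CCK-8 assay, with a stated time of 72 h (a lower number here means a stronger inhibitor, a higher number a weaker inhibitor), compound 1 gives 180 nM and cannot be told apart from compound 3 (190 nM) within the scatter. Compound 2 (40 nM) shows a lower number than compound 1, and that gap lies beyond the scatter.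

Compound 4 `Cn1cc(-c2ccccc2Oc2ccccc2)c2cc(C(=O)NCCCCCC(=O)Nc3ccccc3N)[nH]c2c1=O` has not been measured yet. It carries (2-aminophenyl)carbamoyl in place of (hydroxycarbamoyl)methyl on a saturated chain carbon, five bonds along the chain from an amide-type nitrogen. Compound 2 also carries (2-aminophenyl)carbamoyl and gives 40 nM but differs from compound 1 in other places too. Among the measured compounds shown here, no measured pair shows this change alone, so any forecast stays uncertain. In this assay no step beyond the scatter is expected, and neither direction is favoured. The estimated step runs a 1.1-fold higher number from compound 1 to compound 4 (0.05 log units; within the scatter) and could prove larger either way. For compound 4 the expected value is 200 nM (estimated range 60 nM to 700 nM).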

Compound 4, half-maximal inhibitory concentration: 70 nM
The estimate for compound 4 lay 2.9-fold (0.46 log units) above the measured number; the measured number falls inside the stated range.
By their numbers in this assay, from the lowest: compounds 2 and 4 (each within the scatter of the next); then compounds 1 and 3 (each within the scatter of the next).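

In this assay, putting (2-aminophenyl)carbamoyl in place of (hydroxycarbamoyl)methyl, with the rest of the molecule unchanged, gives a 2.6-fold lower number from compound 1 to compound 4 (0.41 log units; beyond the scatter) on the same chain and core. Among the compounds shown here, this is the first reading of the change on its own: compound 2 also carries (2-aminophenyl)carbamoyl, but it differs in other places too, so it could not isolate this swap. The position on the saturated chain carbon therefore accepts the larger end group, which brings a six-membered aromatic ring, and cell activity improves, though nothing measured here tells why.

Still open, from the compounds shown here alone, is whether a carboxylic acid or a simple amine at this chain end would do as well. It is also unknown how a longer chain bearing (2-aminophenyl)carbamoyl would compare with compound 4.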